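Removing the tert-butoxycarbonyl group from the piperidine carboxamide arm

The source may report more compounds than this note shows. Statements on the series, on what has been measured and on what is new or still open speak of the compounds shown alone.

The series shares the stilbene core of compound 1 `COc1ccc(/C=C\c2cc(OC)c(OC)c(OC)c2)cc1OCc1ccc(C=O)cc1`, which carries a formyl group on the benzyl ether and gives 900 nM in a functional assay on MC-38 cells (Mus musculus) for antiproliferative activity, read by CCK-8 assay, with a stated time of 48 h; on this read-out higher numbers stand for weaker inhibition and lower numbers for stronger inhibition. Compound 3 `COc1ccc(/C=C\c2cc(OC)c(OC)c(OC)c2)cc1OCc1ccc(CNCCNC(C)=O)cc1` replaces that formyl with a ((2-acetamidoethyl)amino)methyl chain and gives 1800 nM; the only shown step, a 2.0-fold higher number from compound 1 to compound 3 (0.30 log units; within the scatter), is within the scatter. Compound 2 `COc1ccc(/C=C\c2cc(OC)c(OC)c(OC)c2)cc1OCc1ccc(CN2CCCCC2C(=O)NCCNC(=O)OC(C)(C)C)cc1` carries a piperidine carboxamide bearing a (tert-butoxycarbonyl)amino terminus and gives 1900 nM. Compound 2 stands at the highest of the three numbers: against compound 3 the gap is within the scatter, against compound 1 it lies beyond it.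

Compound 4 `COc1ccc(/C=C\c2cc(OC)c(OC)c(OC)c2)cc1OCc1ccc(CN2CCCCC2C(=O)NCCN)cc1` differs from compound 2 by hydrogen in place of tert-butoxycarbonyl on an amine nitrogen, that is (tert-butoxycarbonyl)amino to amino. Among the compounds with values here, no measured pair shows this change. Within the data shown here, the one step that exists, the exchange of formyl for an amine-bearing chain from compound 1 to compound 3, stayed within the scatter, and the values of compound 2 and compound 3 sit close together despite different chain ends. On that basis the expected step of a 1.3-fold lower number from compound 2 to compound 4 (0.10 log units; within the scatter) is none beyond the scatter. Compound 4 is therefore estimated at 1500 nM, with a range from 600 nM to 4000 nM.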

Compound 4, half-maximal inhibitory concentration: > 10000 nM
Compound 4 was reported as a limit; the forecaster's own chance of this, stated with the estimate: 3%; middle value at least 6.6-fold (0.82 log units) away from the limit.
By their numbers in this assay, from the lowest: compounds 1, 3 and 2 (each within the scatter of the next, the first and the last beyond it). At a limit, above all of these: compound 4.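

In this assay compound 4 is reported as a limit and not as a number: the limit of > 10000 nM in this assay, at which 1 of the 4 values shown sits.

Within the data shown here, at this position, on an amine nitrogen whose other neighbour is a saturated chain carbon, hydrogen in place of tert-butoxycarbonyl gives an at least 5.2-fold higher number from compound 2 to compound 4 (0.72 log units; beyond the scatter), so the end of this arm can shift the read-out beyond the scatter, which the one earlier step, from formyl to the acetamidoethyl chain, did not show. The comparison with the shorter chain points the same way, with 2-((2-aminoethyl)carbamoyl)piperidin-1-yl in place of (2-acetamidoethyl)amino giving an at least 5.5-fold higher number from compound 3 to compound 4 (0.74 log units; beyond the scatter), though this change covers both the piperidine carboxamide and the chain end and cannot be assigned to either part alone.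

Both steps are bounded on one side only, so their full size remains unknown, and the compounds shown do not separate an effect of the free amino group from one of losing the tert-butoxycarbonyl group. An acetyl group on the same nitrogen, a dimethylamino end or a carboxylic acid in place of the amine would help to tell these two readings apart.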